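The compounds below may be only part of what the source reports. "The series", "measured", "known", "first", "only" and "open" are said of these compounds alone.

Working notes on the series. Compound 1 `O=C(N/N=C\c1ccccn1)c1ccc(-c2nc3ccccc3s2)cc1` and compound 3 `COc1ccc(/C=N/NC(=O)c2ccc(-c3nc4ccccc4s3)cc2)cc1` share the core with compound 2 `O=C(N/N=C/c1cccnc1)c1ccc(-c2nc3ccccc3s2)cc1`; they differ only in the aromatic ring attached to the carbon with a double bond to nitrogen. In an assay on isolated protein for inhibition of Maltase-glucoamylase (Homo sapiens), with a stated time of 15 min (a lower number here means a stronger inhibitor, a higher number a weaker inhibitor), compound 1 gives 10200 nM, and compound 3 gives 18300 nM. Within the data shown here, compound 2 stands apart: in this assay compound 2 is reported as "not active" (no number reported), with no single number, so no step from it to any other compound can be sized.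

Compound 4 `O=C(N/N=C/c1cccc(O)c1)c1ccc(-c2nc3ccccc3s2)cc1` is not yet measured. It differs from compound 2 by 3-hydroxyphenyl in place of pyridin-3-yl on a carbon with a double bond to nitrogen. The change moves the series from a ring with a ring nitrogen toward a carbon-only ring with a hydroxyl, which is closer in kind to compound 3 than to compound 2. With no numeric starting point at compound 2, a step cannot be given; the expectation in this assay is that compound 4 lands near the weak inhibition seen for compound 1 and compound 3, rather than remaining without a number.

The estimate for compound 4 in this assay is 20000 nM, within a range of 6000 nM to 80000 nM, with a real chance that only a limit is reported.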

Compound 4, half-maximal inhibitory concentration: 9210 nM
Compound 4: the middle estimate sits 2.2-fold (0.34 log units) above what was measured; the measured number falls inside the stated range.
By their numbers in this assay, from the lowest: compounds 4, 1 and 3 (each within the scatter of the next).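

In this assay, compound 4 carries a number with 3-hydroxyphenyl at this position, whereas compound 2, with pyridin-3-yl, has none, so the step between these two cannot be read. The remaining steps, a 2.0-fold lower number from compound 3 to compound 4 (0.30 log units; within the scatter) and a 1.1-fold lower number from compound 1 to compound 4 (0.04 log units; within the scatter), do not separate the aromatic rings of compound 1, compound 3 and compound 4 on the carbon with a double bond to nitrogen. No measurement shown here explains why compound 2 stands apart.

On these data alone, it remains open whether the hydroxyl of compound 4 contributes to its number, a question that an unsubstituted phenyl ring would address. As far as these compounds go, it also remains open whether an amine or a carboxylic acid on this ring would give a number in this assay that differs beyond the scatter.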